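A Carbonyl Substituent Swap and Its Expected Consequence

This account rests on a few compounds, and the source may have more. Where it says the series, first, only, none or still open, it means among the compounds named here.

Of the compounds shown here, three built on a shared core have been measured in a functional assay on the whole organism for inhibition of sodium-dependent dopamine transporter (Mus musculus); on this read-out lower numbers stand for an effect already at smaller amounts and higher numbers for an effect only at larger amounts of compound. Compound 2 `CCOC(=O)Nc1cccc2c1CN(C)CC2c1ccccc1` gives 2.5 mg/kg, the lowest of the three numbers. Its nearest neighbour is compound 3 `CCCCOC(=O)Nc1cccc2c1CN(C)CC2c1ccccc1` with 12 mg/kg, and the furthest is compound 1 `CCCCNC(=O)Nc1cccc2c1CN(C)CC2c1ccc(Cl)cc1` with about 120 mg/kg. For the measured compounds named here, the only step between compounds differing in one place is a 4.8-fold higher number from compound 2 to compound 3 (0.68 log units; beyond the scatter), a change of ethyl in place of hydrogen on a saturated chain carbon, two bonds along the chain from an oxygen next to a carbonyl group.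

Compound 4 `CN1Cc2c(NC(=O)CN3CCCCC3)cccc2C(c2ccccc2)C1` has not yet been measured. Relative to compound 2 the difference is (piperidin-1-yl)methyl in place of ethoxy on a carbonyl carbon, sitting on a carbonyl carbon whose other neighbour is an amide-type nitrogen. Going by the values given here, no measured step covers this exchange; the step from compound 2 to compound 3 is the only guide, and there a larger group at that end of the molecule went with a higher number. A rise of similar size is therefore expected, though the new group is unlike any measured one and the uncertainty is wide. Compound 4 is estimated at 8 mg/kg, with a range from 2.5 mg/kg to 25 mg/kg. This estimate means an expected step of a 3.2-fold higher number from compound 2 to compound 4 (0.51 log units; beyond the scatter).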

Compound 4, dose for half-maximal effect: about 60 mg/kg
Beside the measured number, compound 4's estimate is 7.5-fold (0.88 log units) below it, outside the stated range (above it).
By their numbers in this assay, from the lowest: compound 2; then compound 3; then compounds 4 and 1 (each within the scatter of the next).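

In this assay, the carbonyl position proves far less forgiving of (piperidin-1-yl)methyl than the alkoxy series suggested: the exchange for ethoxy gives a 24-fold higher number from compound 2 to compound 4 (1.38 log units; beyond the scatter), and the exchange for butoxy still gives a 5.0-fold higher number from compound 3 to compound 4 (0.70 log units; beyond the scatter). So the new group goes with a higher number than either alkoxy group, and a longer alkoxy chain alone, at a 4.8-fold higher number from compound 2 to compound 3 (0.68 log units; beyond the scatter), did not foreshadow a step of the size seen from the ethoxy compound. Nothing given here explains this rise.

The exchange removes the oxygen on the carbonyl carbon and adds a ring and its nitrogen all at once, so the contribution of each remains unresolved. A cyclohexylmethyl group, which has the ring without its nitrogen, or a simple dimethylaminomethyl group, which has the nitrogen without the ring, would begin to separate them.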